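Fucosidase inhibition notes: methyl for fluoro on the aromatic ring

The compounds below may be only part of what the source reports. "The series", "measured", "known", "first", "only" and "open" are said of these compounds alone.

Measured so far in an assay on isolated protein for inhibition of tissue alpha-L-fucosidase (Bos taurus), tested at 1000 uM; on this read-out higher numbers stand for more inhibition at the one concentration tested (going by the name of the read-out) and lower numbers for less inhibition:
compound 1 `OC[C@]1(c2ccc(F)cc2)NC[C@H](O)[C@H]1O` gives 0%
compound 2 `OC[C@]1(c2cccc(F)c2)NC[C@H](O)[C@H]1O` gives 0%
compound 3 `CCCC[C@]1(CO)NC[C@@H](O)[C@@H]1O` gives 20.8%

Compound 1 stands level with compound 2 at the digits reported, and together these two are the lowest of the three numbers. Compound 3 is the furthest away from compound 1, its reading higher by a difference that lies beyond the usual scatter of this read-out. For the measured compounds named here, no pair among the measured compounds differs in one place only, so there is no measured single-point step to lean on.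

Compound 4 `Cc1ccc([C@@]2(CO)NC[C@H](O)[C@H]2O)cc1` is the next compound to be run in this assay. It differs from compound 1 by methyl in place of fluoro on an aromatic carbon. Going by the values given here, none of the measured compounds carries a methyl on the aromatic ring, and the only variation seen on that ring so far, between compound 1 and compound 2, leaves the reading unchanged at the digits reported. The shared core of compound 1 with an aromatic group attached has so far shown no inhibition in this assay.

The step expected from compound 1 to compound 4 is a number 4 percentage points higher from compound 1 to compound 4 (within the scatter), that is, none beyond the scatter. Compound 4 is therefore estimated at 4%, with a range from 0% to 18%.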

Compound 4, a percentage reported as inhibition, at one concentration (the size of the read-out at that concentration, not a potency): 3.3%
The estimate for compound 4 lay 0.7 percentage points above the measured number, and the stated range covers the measured number.
By their numbers in this assay, from the lowest: compounds 1, 2 and 4 (each within the scatter of the next); then compound 3.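

In this assay, for the compounds shown here, the exchange gives the first measured single-place step: methyl in place of fluoro on an aromatic carbon, para to a group of 9 heavy atoms, is a number 3.3 percentage points higher from compound 1 to compound 4 (within the scatter) and so stays inside the usual scatter. At this position, the read-out at its one concentration does not separate the two single-heavy-atom groups, with compound 1 at 0% and compound 4 at 3.3%, and inhibition stays close to nil with either group on the ring. No measurement shown here bears on why the reading stays at this level.

Still open, as far as these compounds go, is whether a carboxylic acid, an amine or a longer chain at this same aromatic carbon would give a reading beyond the scatter, as neither fluoro nor methyl tests a group of that kind. Also open, from the compounds shown here alone, is whether methyl on another carbon of the ring would match the reading of compound 4, and whether compound 1 and compound 4 would separate at any other concentration.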